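A few compounds are considered here, and "the series" means these few. Any claim that something is new, unique, unknown or untested is made for them only; others in the source may bear on it.

Measured compounds:
- compound 1, `Cc1ccc2nc(-c3ccc(NCc4cn(Cc5cc(=O)oc6cc(O)ccc56)nn4)cc3)sc2c1`: 16200 nM in a functional assay on A549 cells (Homo sapiens) for inhibition, read by MTT assay, with a stated time of 72 h; on this read-out lower numbers stand for stronger inhibition and higher numbers for weaker inhibition
- compound 2, `Cc1ccc2c(Cn3cc(CNc4ccc(-c5nc6ccc(C)cc6s5)cc4)nn3)cc(=O)oc2c1`: 46200 nM in this assay
- compound 3, `O=c1cc(Cn2cc(-n3ccc4cc(I)ccc43)nn2)c2ccc(O)cc2o1`: 28600 nM in this assay

Compound 1 and compound 2 share a core and differ in one place, (methyl in place of hydroxy on an aromatic carbon). That change gave a 2.9-fold higher number from compound 1 to compound 2 (0.46 log units; beyond the scatter).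

Compound 3 sits on a different core; the difference between the core of compound 3 and the core of compound 1 is not broken down here. Its value in this assay lies within the scatter of both compound 1 and compound 2, so no order among the three is claimed.

Compound 4, `Cc1ccc2c(Cn3cc(-n4ccc5cc(I)ccc54)nn3)cc(=O)oc2c1`, is not yet measured. It differs from compound 3 in one place, (methyl in place of hydroxy on an aromatic carbon), and the two place descriptions agree word for word with those for the change from compound 1 to compound 2, so this is the same change on a second core. Within the data shown here, only one measured instance of the change exists, and it is on a core whose relation to the core of compound 3 is not broken down here, so the transfer is uncertain.

For compound 4 in this assay a step of about a 2.6-fold higher number from compound 3 to compound 4 (0.42 log units; beyond the scatter) is expected, resting on the step of a 2.9-fold higher number from compound 1 to compound 2 (0.46 log units; beyond the scatter) and on compound 3 giving 28600 nM. Compound 4 is therefore estimated at 75000 nM, with a likely range from 30000 nM to 190000 nM.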

Compound 4, half-maximal inhibitory concentration: 34100 nM
Beside the measured number, compound 4's estimate is 2.2-fold (0.34 log units) above it, within the range that was stated.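

Read on the second core in this assay, methyl in place of hydroxy gives a 1.2-fold higher number from compound 3 to compound 4 (0.08 log units; within the scatter), a step that on its own cannot be told from the scatter of repeated measurements. Set beside the earlier step on the first core, it does not differ from that step by more than two such steps can scatter: the same change on two cores in this assay, a 2.9-fold higher number (0.46 log units; beyond the scatter) from compound 1 to compound 2 and a 1.2-fold higher number (0.08 log units; within the scatter) from compound 3 to compound 4, 2.4-fold (0.38 log units) apart, within the scatter of two such steps. This shows that the two pairs do not contradict one shared step for the change, but it does not show that the step carries over, since the same numbers also fit a real step on the first core and none on the second, and two pairs fix no size for the change.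

The compounds shown carry only hydroxy or methyl at this aromatic carbon, which leaves open how an amine, a methoxy group or a carboxylic acid in that place would read in this assay. From the compounds shown here alone, it also remains open whether a further matched pair on a third core would fall nearer the larger or the smaller of the two steps.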